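Swapping a Nitrile for Fluorine on Compound 2

The source may report more compounds than this note shows. Statements on the series, on what has been measured and on what is new or still open speak of the compounds shown alone.

compound 1 `O=C(O)CNC(=O)c1cc2ccccc2oc1=O` gives 1%
compound 2 `COc1cccc2cc(C(=O)Nc3c(C#N)ncn3-c3ccc(C#N)cc3)c(=N)oc12` gives 18%
compound 3 `CCC(CO)NC(=O)c1cc2cccc(OC)c2oc1=N` gives 24%

In an assay on CHO cells for displacement of a labelled ligand from adenosine receptor A1 (Homo sapiens), read by scintillation counting, with a stated time of 60 min, tested at 10 uM (a lower number here means less inhibition, a higher number more inhibition at the concentration tested (going by the name of the read-out)), compound 2 stands second highest of the three numbers. Its nearest neighbour is compound 3, a gap within the scatter, and its furthest is compound 1, whose lower number lies beyond the scatter. Compound 4 `COc1cccc2cc(C(=O)Nc3c(C#N)ncn3-c3ccc(F)cc3)c(=N)oc12` has not been measured; it differs from compound 2 by fluoro in place of cyano on an aromatic carbon. Going by the values given here, no pair of measured compounds shows this change on its own, so nothing in the data tells how big a step it brings. The change is expected to give a step of a number 3 percentage points lower from compound 2 to compound 4 (within the scatter), which would be none beyond the scatter. Compound 4 is therefore estimated at 15%, in the range 3% to 30%.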

Compound 4, a percentage reported as inhibition, at one concentration (the size of the read-out at that concentration, not a potency): 46%
Compound 4: middle estimate off by 31 percentage points, on the low side; the whole stated range lies below it.
By their numbers in this assay, from the lowest: compound 1; then compounds 2 and 3 (each within the scatter of the next); then compound 4.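

In this assay, fluoro in place of cyano on the aromatic carbon para to a large group brings a step of a number 28 percentage points higher from compound 2 to compound 4 (beyond the scatter) and so shows that the read-out responds to this position. The earlier compounds shown here differ from one another in more than one place, so they could not show this for the 4-cyanophenyl group alone. Nothing at hand explains the step.

On these data alone, whether the rise comes from fluoro itself or from the loss of the nitrile stays open. So does what a chlorine, an amine or an unsubstituted phenyl ring would give here.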